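Methyl removed from the oxygen: compound 3 to compound 4

A few compounds are considered here, and "the series" means these few. Any claim that something is new, unique, unknown or untested is made for them only; others in the source may bear on it.

Three compounds sharing one core were examined in a functional assay on PC-3 cells (Homo sapiens) for cytotoxicity, read by sulforhodamine B assay, with a stated time of 48 h, tested at 1 uM; a higher number here means a weaker effect of the compound at the concentration tested, a lower number a stronger effect. Compound 1 `COc1cc(C)cc(-c2c(-c3ccnc(-c4ccc(C(C)=O)cc4)c3)cnn2CC#N)c1` gives 24%, compound 2 `Cc1cc(O)cc(-c2nn(CC#N)cc2-c2ccnc(-c3ccc(Oc4ccccc4)cc3)c2)c1` gives -12%, and compound 3 `COc1cc(C)cc(-c2nn(CC#N)cc2-c2ccnc(-c3ccc(N(C)C)cc3)c2)c1` gives 17%. Compound 3 stands second highest of the three; its number and that of compound 1 lie within the usual scatter of each other, while compound 2 sits clearly lower, beyond the scatter.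

Compound 4 `Cc1cc(O)cc(-c2nn(CC#N)cc2-c2ccnc(-c3ccc(N(C)C)cc3)c2)c1` has not yet been measured. It differs from compound 3 in one place: hydrogen in place of methyl on an oxygen on an aromatic ring. Among the compounds with values here, no pair of measured compounds differs by this change alone, so no directly comparable step is known. Compound 2, which also carries a hydroxy, gave the lowest number of the three. Compound 4 is therefore expected to give a somewhat lower number than compound 3, a step of a number 12 percentage points lower from compound 3 to compound 4 (beyond the scatter), with an estimate of 5% in this assay, within a range of -20% to 30%.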

Compound 4, a percentage reported as activity, at one concentration (the size of the read-out at that concentration, not a potency): 18%
Beside the measured number, compound 4's estimate is 13 percentage points below it; low and high end bracket the measured number.
By their numbers in this assay, from the lowest: compound 2; then compounds 3, 4 and 1 (each within the scatter of the next).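

In this assay, methoxy to hydroxy gives a number 1 percentage points higher from compound 3 to compound 4 (within the scatter), so with dimethylamino present, this change on the oxygen leaves no readable difference. With hydroxy held fixed, dimethylamino in place of phenoxy gives a number 30 percentage points higher from compound 2 to compound 4 (beyond the scatter), so the low number of compound 2 does not come with hydroxy alone. No measurement shown gives a reason for either step.

As far as these compounds go, whether ethoxy on that oxygen, or an amine in its place, would give a similar number stays open. So does whether methoxy and hydroxy also match when phenoxy is present.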